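The source may hold more compounds than are shown below. What is called first, only, known or untested is meant among the compounds shown, and "the series" means these compounds.

Three compounds were measured in an ADME assay on WI-38 cells (Homo sapiens) for cytotoxicity, read by MTT assay, with a stated time of 72 h; on this read-out lower numbers stand for stronger inhibition and higher numbers for weaker inhibition:

Compound 1 `CN(C)CCn1cnnc1-c1cc(Oc2ccc(NC(=O)N/N=C/c3ccc(F)cc3)cc2F)ccn1` gives 3980 nM
Compound 2 `CN(C)CCn1cnnc1-c1cc(Oc2ccc(NC(=O)N/N=C/c3cccc(Cl)c3Cl)cc2F)ccn1` gives 6130 nM
Compound 3 `CN(C)CCn1cnnc1-c1cc(Oc2ccc(NC(=O)N/N=C/c3cccc(Br)c3)cc2F)ccn1` gives 4230 nM

Among these three numbers compound 3 holds the second highest place, but its neighbours are close on either side: the step of a 1.1-fold higher number from compound 1 to compound 3 (0.03 log units; within the scatter) and the step of a 1.4-fold lower number from compound 2 to compound 3 (0.16 log units; within the scatter) both stay within the scatter, so the three compounds cannot be told apart on this read-out.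

Compound 4 `CN(C)CCn1cnnc1-c1cc(Oc2ccc(NC(=O)N/N=C/c3ccc(F)cc3Cl)cc2F)ccn1` has not yet been measured. It differs from compound 3 in one place: 2-chloro-4-fluorophenyl in place of 3-bromophenyl on a carbon with a double bond to nitrogen. Every step measured so far changes the same aryl group on the carbon with a double bond to nitrogen: a 1.5-fold higher number from compound 1 to compound 2 (0.19 log units; within the scatter), a 1.1-fold higher number from compound 1 to compound 3 (0.03 log units; within the scatter) and a 1.4-fold lower number from compound 2 to compound 3 (0.16 log units; within the scatter), and none of them leaves the scatter. Swapping one halogenated phenyl ring for another at this position has therefore produced no step beyond the scatter in this assay, whichever halogens were present. On that basis the step to compound 4 is expected to be a 1.1-fold higher number from compound 3 to compound 4 (0.05 log units; within the scatter), that is, no change beyond the scatter in either direction.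

Compound 4 is thus estimated at 4700 nM in this assay, within a range of 2300 nM to 9500 nM.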

Compound 4, half-maximal inhibitory concentration: 2090 nM
For compound 4 the middle estimate is 2.2-fold (0.35 log units) above the measured one; measured number outside the range, below it.
By their numbers in this assay, from the lowest: compounds 4, 1, 3 and 2 (each within the scatter of the next, the first and the last beyond it).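

In this assay, going by these compounds alone, the aryl group on the carbon with a double bond to nitrogen, which had so far given only steps within the scatter, now gives two modest steps beyond it (a 2.0-fold lower number from compound 3 to compound 4 (0.31 log units; beyond the scatter)) and (a 2.9-fold lower number from compound 2 to compound 4 (0.47 log units; beyond the scatter)). The third step, where chloro stands in place of hydrogen on an aromatic carbon, stays within the scatter (a 1.9-fold lower number from compound 1 to compound 4 (0.28 log units; within the scatter)), so that single change cannot be told apart from repeat variation, and compound 4 separates only from compound 2 and compound 3. Which halogens the phenyl ring carries can therefore shift the number at this position, if only modestly, but no measurement given here bears on why this happens.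

The compounds shown all carry at least one halogen on this phenyl ring, so they leave open whether an unsubstituted phenyl, a methoxy group, an amine or a carboxylic acid on that ring would stay in the same range in this assay. They also leave open whether the same aryl changes would give similar steps if the dimethylaminoethyl chain on the shared core were replaced.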